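Ester to carboxylic acid: expectation for compound 3

A few compounds are considered here, and "the series" means these few. Any claim that something is new, unique, unknown or untested is made for them only; others in the source may bear on it.

Measured compounds:
compound 1 `Cc1ccc(N2C(=O)N/C(=C\c3ccc(O)cc3)C2=O)cc1`
compound 2 `CCOC(=O)c1ccc(N2C(=O)N/C(=C\c3ccc(O)cc3)C2=O)cc1`

In a functional assay on NCI-H292 cells (Homo sapiens) for antiproliferative activity (a higher number here means a weaker inhibitor, a lower number a stronger inhibitor), compound 1 gives 27900 nM. Compound 2 gives > 200000 nM, which is a limit of the assay and not a number. Among the compounds with values here, the one measured step, an at least 7.1-fold higher number from compound 1 to compound 2 (0.85 log units; beyond the scatter), is therefore bounded only on one side, since one of the two values sits at the limit of > 200000 nM in this assay, at which 1 of the 2 values shown sits. Compound 3 `O=C(O)c1ccc(N2C(=O)N/C(=C\c3ccc(O)cc3)C2=O)cc1` differs from compound 2 by hydrogen in place of ethyl on an oxygen next to a carbonyl group. Within the data shown here, no measured step covers this change; the step from compound 1 to compound 2 concerns a different group and only fixes where compound 2 stands, namely at the limit. With nothing to indicate a gain, no movement beyond the scatter in this assay is expected, and a repeat at the limit is the most likely outcome. The estimate for compound 3 is 200000 nM, with a range of 60000 nM to 600000 nM. This corresponds to an expected step of a number no higher from compound 2 to compound 3 (the limit leaves the size open).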

Compound 3, half-maximal inhibitory concentration: > 200000 nM
Compound 3: only a limit was reported; the forecaster's own chance of this, stated with the estimate: 70%; the middle value sits exactly at the limit.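

With carboxy, as with ethoxycarbonyl, on this aromatic carbon, the series stays at the limit of this assay: the limit of > 200000 nM in this assay, at which 2 of the 3 values shown sit.

Carboxy in place of the methyl of compound 1 gives an at least 7.1-fold higher number from compound 1 to compound 3 (0.85 log units; beyond the scatter), a bounded reading of the same kind as an at least 7.1-fold higher number from compound 1 to compound 2 (0.85 log units; beyond the scatter), so both groups tested against methyl leave the series on the weak side of it. The step between the two limits cannot be read, so hydrogen in place of ethyl on an oxygen next to a carbonyl group has no size in this series.

Where compound 2 and compound 3 would fall as actual numbers stays open, as both readings are limits. Also open, on these data alone, is whether an amine, a chlorine atom or a longer alkyl chain such as propyl on this aromatic carbon would match or improve on methyl.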